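The source may hold more compounds than are shown below. What is called first, only, known or untested is meant among the compounds shown, and "the series" means these compounds.

Of the compounds shown here, three have so far been measured in a functional assay on UACC-257 cells (Homo sapiens) for cytotoxicity, read by sulforhodamine B assay, with a stated time of 48 h, tested at 10 uM; on this read-out lower numbers stand for a stronger effect and higher numbers for a weaker effect at the one concentration tested. Compound 1, with the structure `COc1ccc(-c2cc(/C=C/C(=O)c3ccc(N)cc3)[nH]n2)cc1`, gives -54% in this assay. Compound 3, with the structure `COc1ccc(-c2cc(/C=C/C(=O)c3ccc(N)cc3)[nH]n2)cc1OC`, gives 39% in this assay. Compound 3 differs from compound 1 by methoxy in place of hydrogen on an aromatic carbon, and this change brought a number 93 percentage points higher from compound 1 to compound 3 (beyond the scatter). Compound 2, with the structure `COc1ccc(C(=O)/C=C/c2cc(-c3cc(OC)c(OC)c(OC)c3)n[nH]2)cc1OC`, gives -98% in this assay, the lowest of the three numbers. The difference between the core of compound 2 and the core of compound 1 is not broken down here.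

Compound 4, with the structure `COc1cc(C(=O)/C=C/c2cc(-c3cc(OC)c(OC)c(OC)c3)n[nH]2)cc(OC)c1OC`, is not yet measured. It differs from compound 2 by methoxy in place of hydrogen on an aromatic carbon. Within the data shown here, this is the same kind of change as the one from compound 1 to compound 3, but not the same: in compound 4 the place of change is also meta to a methoxy group, which is not the case at the place of change in compound 3.

For compound 4 the expected step is a number 58 percentage points higher from compound 2 to compound 4 (beyond the scatter). This expectation rests on a single earlier example, a number 93 percentage points higher from compound 1 to compound 3 (beyond the scatter), together with the fact that the two cores differ in a way that is not broken down, which makes the transfer uncertain and argues for a more cautious step. The estimated value of compound 4 in this assay is -40%, expected to fall between -100% and 40%.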

Compound 4, a percentage reported as activity, at one concentration (the size of the read-out at that concentration, not a potency): -93%
Beside the measured number, compound 4's estimate is 53 percentage points above it; low and high end bracket the measured number.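

In this assay the methoxy group that replaces a hydrogen on an aromatic carbon of compound 2 gives a number 5 percentage points higher from compound 2 to compound 4 (within the scatter) and so leaves the read-out effectively unchanged. The same kind of change on the other core gave a clearly different result, and the two steps do not agree: the same change on two cores in this assay, a number 93 percentage points higher (beyond the scatter) from compound 1 to compound 3 and a number 5 percentage points higher (within the scatter) from compound 2 to compound 4, 88 percentage points apart, beyond the scatter of two such steps. Among these compounds, this shows that, in this series, the change cannot be carried from one core to another as a fixed shift in the read-out, but with only two pairs it does not show what sets the two results apart, since the cores differ and the places of change differ too.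

The compounds shown leave open how a third core would respond, and whether it would resemble the large step seen on the core of compound 1 or the step within the scatter seen on the core of compound 2. They also leave open whether another group at the same place on the core of compound 2, such as a hydroxy group, an ethoxy group or a chlorine atom, would move the read-out any more than methoxy does.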